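A few compounds are considered here, and "the series" means these few. Any claim that something is new, unique, unknown or untested is made for them only; others in the source may bear on it.

Compound 2 `CCCn1cnc2ncnc(N)c21` was tested in a functional assay on CHO cells for antagonist activity at adenosine receptor A2b (Homo sapiens); on this read-out higher numbers stand for weaker inhibition and lower numbers for stronger inhibition. In this assay compound 2 gives > 30000 nM, which is a limit of the assay rather than a number. Compound 1 `CCn1cnc2ncnc(N)c21` likewise gives > 30000 nM, also only a limit. The step that the two limits leave unreadable from compound 1 to compound 2 therefore cannot be read. Compound 3 `CC(C)Cn1cnc2ncnc(N)c21` differs from compound 2 by methyl in place of hydrogen on a saturated chain carbon bound to two saturated chain carbons. Among the compounds with values here, the only evidence is the limit of > 30000 nM in this assay, at which 2 of the 2 values shown sit, so no direction can be expected beyond another limit. Compound 3 is expected to give 40000 nM, with a range from 10000 nM to 150000 nM. The expected step is estimated as a step that the limit leaves unreadable from compound 2 to compound 3, essentially no change.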

Compound 3, inhibition constant: > 30000 nM
Compound 3: no number, only a limit (the forecaster's own chance of this, stated with the estimate: 85%); the middle value does not contradict the limit.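

Compound 1, compound 2 and compound 3 each give only a limit of the assay, not a number, so the steps among them cannot be read. On these data alone, whether these chains differ at all in this assay stays open.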